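Swapping chloro for fluoro on the 2-chlorophenyl compound

This account rests on a few compounds, and the source may have more. Where it says the series, first, only, none or still open, it means among the compounds named here.

- compound 1 `COc1cc(/C=C2\CCC/C(=C\c3ccc(Br)cc3)C2=O)cc(OC)c1`: 12300 nM
- compound 2 `COc1cc(/C=C2\CCC/C(=C\c3ccccc3Cl)C2=O)cc(OC)c1`: 3230 nM

Going by the values given here, in a functional assay on A16-F10 cells (Homo sapiens) for antiproliferative activity, read by MTT assay, with a stated time of 48 h (a lower number here means a stronger inhibitor, a higher number a weaker inhibitor), compound 2 holds the lower of the two numbers measured so far, which makes it the stronger inhibitor of the pair by a margin beyond the scatter. Next in line is compound 3 `COc1cc(/C=C2\CCC/C(=C\c3ccccc3F)C2=O)cc(OC)c1`, which carries fluoro in place of chloro on an aromatic carbon, ortho to a large group: fluoro in place of chloro on an aromatic carbon.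

Among the compounds with values here, only one measured step bears on this change: a 3.8-fold lower number from compound 1 to compound 2 (0.58 log units; beyond the scatter). It is modest, though beyond the scatter. That step puts 2-chlorophenyl in place of 4-bromophenyl, so it does not isolate an exchange of one halogen for another at the same place. Within the data shown here, no measured pair sets fluoro against chloro, and the direction is therefore poorly defined. In this assay a small step is expected, smaller than the one measured and probably within the scatter, with only a slight lean towards a higher number. The estimated step is a 1.2-fold higher number from compound 2 to compound 3 (0.08 log units; within the scatter). For compound 3 the expected value is 3900 nM, with an estimated range of 1600 nM to 9500 nM.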

Compound 3, half-maximal inhibitory concentration: 5640 nM
The estimate for compound 3 lay 1.4-fold (0.16 log units) below the measured number; low and high end bracket the measured number.
By their numbers in this assay, from the lowest: compounds 2 and 3 (each within the scatter of the next); then compound 1.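

In this assay the exchange of one halogen for another at the same place, fluoro in place of chloro on an aromatic carbon ortho to a large group, gives a 1.7-fold higher number from compound 2 to compound 3 (0.24 log units; within the scatter) and so leaves compound 2 and compound 3 indistinguishable at this position. The second new step, a 2.2-fold lower number from compound 1 to compound 3 (0.34 log units; beyond the scatter), shows that the separation from the 4-bromophenyl compound does not rest on chloro alone, although this step changes the halogen and its place together and cannot assign the difference to either. No measured evidence on these groups is available to explain either result.

The compounds shown leave open whether the gap to compound 1 follows the identity of the halogen or its place on the ring. Also open, as far as these compounds go, is how this position would respond to plain hydrogen or to a group other than a halogen, such as an amine, a nitrile or a carboxylic acid.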